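Pentyl in place of thiophen-2-yl: expected cytotoxicity

The source may hold more compounds than are shown below. What is called first, only, known or untested is meant among the compounds shown, and "the series" means these compounds.

Measured so far:
Compound 1 `O=C(CCCCC(=O)Nc1ncc(Cc2ccc(F)cc2)s1)Nc1ncc(Cc2ccc(F)cc2)s1`: > 50000 nM
Compound 2 `O=C(Nc1ncc(C(Oc2ccc3cc(Br)ccc3c2)c2ccc(Cl)cc2)s1)c1cccs1`: "not toxic" (no number reported)

Both results come from an ADME assay on HepG2 2.2.15 cells (Homo sapiens) for cytotoxicity; a lower number here means that less compound is tolerated, a higher number that more compound is tolerated. For compound 1 the value is a limit of the assay rather than a number (the limit of > 50000 nM in this assay, at which 1 of the 2 values shown sits). Compound 2 has no single number at all; it is simply reported as tolerated, so it stands at the non-toxic end of this assay together with compound 1, without a figure to compare.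

Compound 3 `CCCCCC(=O)Nc1ncc(C(Oc2ccc3cc(Br)ccc3c2)c2ccc(Cl)cc2)s1` has not yet been measured. It differs from compound 2 in one place: pentyl in place of thiophen-2-yl on a carbonyl carbon. Going by the values given here, no measured pair shows this change, so no measured step size exists for it. Both measured compounds sit at the tolerated end, and for this assay the expectation is no shift beyond the usual scatter. Compound 3 is therefore expected to give 50000 nM, within 20000 nM to 100000 nM, most likely again reported only as a limit.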

Compound 3, half-maximal cytotoxic concentration: > 50000 nM
Compound 3: no number, only a limit; the forecaster's own chance of this, stated with the estimate: 80%; the middle value lies on the limit itself.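

Neither compound 2 nor compound 3 carries a plain number in this assay, so no step can be read between them. The compounds shown leave open at what concentration, if any, compound 2 and compound 3 harm these cells, and whether swapping thiophen-2-yl for pentyl changes that concentration.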